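This account rests on a few compounds, and the source may have more. Where it says the series, first, only, none or still open, it means among the compounds named here.

For the measured compounds named here, compound 1 `c1ccc(-c2noc(Cc3c[nH]c4ccccc34)n2)cc1` is the first of the three measured compounds. In a functional assay on cells (Splenocyte, Mus musculus, strain BALB/c) for inhibition, read by scintillation counting and thymidine incorporation, with stated times of 48 h and 8 h (a higher number here means a weaker inhibitor, a lower number a stronger inhibitor), compound 1 gives > 50000 nM, which is a limit of the assay and not a number.
Compound 2 `COc1cc(-c2noc(-c3ccccc3)n2)cc(OC)c1OC` follows. In this assay compound 2 gives > 50000 nM, again a limit of the assay.
Going by the values given here, compound 3 `COc1cc(-c2noc(C3CC4(C3)CC(F)(F)C4)n2)cc(OC)c1OC` is the only one with a number. In this assay compound 3 gives 5200 nM.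

Compound 2 therefore stands at the limit of > 50000 nM in this assay, at which 2 of the 3 values shown sit, so its place among the three is known only as a limit, and the numbers shown give no step between any two measured compounds that differ in one place.

The unmeasured compound 4 `CCCCCCc1ccc(-c2nc(-c3cc(OC)c(OC)c(OC)c3)no2)cc1` differs from compound 2 in one place: hexyl in place of hydrogen on an aromatic carbon. Among the compounds with values here, no measured pair shows what such a change does in this assay, so any expectation rests on compound 2 alone, whose value is a limit. An account of this kind can only say that compound 4 is expected to remain in the weak region, with a step from compound 2 that may be none beyond the scatter, or a modest move toward stronger inhibition, expected as an at least 2.0-fold lower number from compound 2 to compound 4 (0.30 log units; that floor lies within the scatter). For compound 4 the estimate in this assay is 25000 nM, with a range from 6000 nM to 90000 nM.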

Compound 4, half-maximal inhibitory concentration: 23800 nM
Estimate against measurement, compound 4: 1.1-fold (0.02 log units) above; low and high end bracket the measured number.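

Hexyl in place of hydrogen on an aromatic carbon, para to a large group, gives the first step that can be read in this series: in this assay there is an at least 2.1-fold lower number from compound 2 to compound 4 (0.32 log units; beyond the scatter). For the compounds shown here, the earlier compounds offered no pair differing in one place, so this is the first sign that this position of the six-membered aromatic ring can be changed with a measurable result, and that the change in this pair goes toward stronger inhibition. The step is only a floor, and its true size stays unknown, because its starting point for compound 2 is a limit of the assay and not a number: the limit of > 50000 nM in this assay, at which 2 of the 4 values shown sit.

The compounds shown leave open whether a shorter chain such as butyl, a longer chain such as decyl, or an amine or a carboxylic acid on the same carbon would move the number further, less or not at all. They also do not tell whether hexyl would give a similar step at another position of that ring, or with a different group on the other side of the shared core.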